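The source may report more compounds than this note shows. Statements on the series, on what has been measured and on what is new or still open speak of the compounds shown alone.

Among the measured compounds shown here, the three compounds measured so far share one core and differ in the group attached to it. Compound 1 `Nc1cc(N)c2nc(-c3ccccc3)c(Oc3ccc(Cl)c(Cl)c3)nc2c1` carries a 3,4-dichlorophenoxy group, compound 3 `Nc1cc(N)c2nc(-c3ccccc3)c(Sc3ccc(F)cc3)nc2c1` a (4-fluorophenyl)sulfanyl group, and compound 2 `Nc1cc(N)c2nc(-c3ccccc3)c(NCc3ccc(Cl)c(Cl)c3)nc2c1` a 3,4-dichlorobenzyl amine. In a functional assay on M14 cells (Homo sapiens) for inhibition, read by sulforhodamine B assay, with a stated time of 48 h (on this read-out higher numbers stand for weaker inhibition of growth and lower numbers for stronger inhibition of growth), compound 1 gives 14100 nM, compound 3 gives 15800 nM and compound 2 gives 15800 nM. The only step between two compounds differing in one place, a 1.1-fold higher number from compound 1 to compound 3 (0.05 log units; within the scatter), lies within the scatter, and compound 2 stands level with compound 3 at the digits shown and within the scatter of compound 1; the three numbers cannot be told apart.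

Compound 4 `COc1ccc(CNc2nc3cc(N)cc(N)c3nc2-c2ccccc2)cc1` has not yet been measured. It differs from compound 2 by 4-methoxyphenyl in place of 3,4-dichlorophenyl on a saturated chain carbon bound to a nitrogen on an aromatic ring. For the measured compounds named here, no measured step touches that part of the molecule: the one measured step concerns a different attachment to the core, and it was within the scatter. The data therefore give no ground for expecting a step beyond the scatter, in either direction, and the expectation is that a 1.0-fold higher number from compound 2 to compound 4 (0.01 log units; within the scatter) remains within it. Compound 4 is accordingly estimated at 16000 nM, with a range from 6000 nM to 45000 nM, in this assay.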

Compound 4, concentration for 50% growth inhibition: 18200 nM
Compound 4: middle estimate off by 1.1-fold (0.06 log units), on the low side; measured number inside the range.
By their numbers in this assay, from the lowest: compounds 1, 2, 3 and 4 (each within the scatter of the next).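

Among the compounds shown here, on a saturated chain carbon bound to a nitrogen on an aromatic ring, 4-methoxyphenyl in place of 3,4-dichlorophenyl gives a 1.2-fold higher number from compound 2 to compound 4 (0.06 log units; within the scatter) in this assay, and this is the first measured step at this place. The change is not a small one on paper: both chlorine atoms leave, an oxygen enters, and the entering group counts one hydrogen-bond acceptor where the leaving group counts none, yet the read-out does not separate compound 4 from compound 2, so for these two benzyl groups the swap leaves growth inhibition unchanged within the scatter. No supporting information bears on why the two compounds cannot be told apart.

Whether a dimethylamino group or a carboxylic acid on the benzyl ring, or a phenethyl amine in place of the benzyl amine, would carry the number beyond the scatter stays open, since every step shown so far lies within it. The phenyl group on the shared core is the same in all four compounds, so nothing here speaks to a pyridyl group or a cyclohexyl group in its place.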